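Swapping the fluorinated chain from compound 3 to compound 4

A few compounds are considered here, and "the series" means these few. Any claim that something is new, unique, unknown or untested is made for them only; others in the source may bear on it.

In an ADME assay on liver (Homo sapiens) for metabolic stability, using microsomes (a higher number here means that the compound lasts longer, a lower number that the compound disappears faster), compound 1 `COc1cnc(O[C@@H]2C[C@@H](C(=O)N[C@]3(C(=O)NS(=O)(=O)C4CC4)C[C@H]3C3CC3)N(C(=O)[C@@H](NC(=O)OC3(C)CCCC3)C(C)(C)C)C2)c2cc(Cl)ccc12` gives 0.4 h, compound 2 `COc1cnc(O[C@@H]2C[C@@H](C(=O)N[C@]3(C(=O)NS(=O)(=O)C4CC4)C[C@H]3C3CC3)N(C(=O)[C@@H](NC(=O)OC(C)(C)C(F)(F)F)C(C)(C)C)C2)c2cc(Cl)ccc12` gives 2.13 h and compound 3 `COc1cnc(O[C@@H]2C[C@@H](C(=O)N[C@]3(C(=O)NS(=O)(=O)C4CC4)C[C@H]3C3CC3)N(C(=O)[C@@H](NC(=O)OC(C)(C)C(F)F)C(C)(C)C)C2)c2cc(Cl)ccc12` gives 2 h. Compound 3 therefore stands level with compound 2, and both stand clear of compound 1.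

Compound 4 `COc1cnc(O[C@@H]2C[C@@H](C(=O)N[C@]3(C(=O)NS(=O)(=O)C4CC4)C[C@H]3C3CC3)N(C(=O)[C@@H](NC(=O)O[C@H](C)C(F)(F)F)C(C)(C)C)C2)c2cc(Cl)ccc12` differs from compound 3 by 1-(trifluoromethyl)ethyl in place of 1-(difluoromethyl)-1-methylethyl on an oxygen next to a carbonyl group.

Three measured steps at this place bear on the change. Two are modest, a 5.3-fold higher number from compound 1 to compound 2 (0.73 log units; beyond the scatter) and a 5.0-fold higher number from compound 1 to compound 3 (0.70 log units; beyond the scatter), and both start from the 1-methylcyclopentyl group. The closest is a 1.1-fold lower number from compound 2 to compound 3 (0.03 log units; within the scatter), where hydrogen replaces fluoro on a fluorinated chain. Among the measured compounds shown here, no measured step covers the exact exchange in compound 4, which leaves the estimate uncertain.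

The expected step is a 1.3-fold lower number from compound 3 to compound 4 (0.10 log units; within the scatter), and it is not expected to go beyond the scatter. The estimate for compound 4 is 1.6 h, with an expected range of 0.7 h to 3.5 h.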

Compound 4, half-life: 2.12 h
Estimate against measurement, compound 4: 1.3-fold (0.12 log units) below, and the stated range covers the measured number.
By their numbers in this assay, from the lowest: compound 1; then compounds 3, 4 and 2 (each within the scatter of the next).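

In this assay, the 1-(trifluoromethyl)ethyl group on this oxygen sits level with both fluorinated chains that carry an extra methyl, with a 1.1-fold higher number from compound 3 to compound 4 (0.03 log units; within the scatter) and with a 1.0-fold lower number from compound 2 to compound 4 (0.00 log units; within the scatter). The gain over the 1-methylcyclopentyl group therefore persists without that methyl, at a 5.3-fold higher number from compound 1 to compound 4 (0.72 log units; beyond the scatter), and all three fluorinated groups shown form a single level, with compound 1 as the only one apart. Nothing on hand explains this flat response.

Compound 1 also differs from the other three in more than its fluorine atoms, so these compounds do not separate the contribution of the fluorine from that of the ring. Going by these compounds, a plain isopropyl or tert-butyl group on the same oxygen would address that, and the opposite configuration at the defined stereocentre of the 1-(trifluoromethyl)ethyl group remains open as well.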